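Ester to acid on a dimethyl-substituted analogue

The source may hold more compounds than are shown below. What is called first, only, known or untested is meant among the compounds shown, and "the series" means these compounds.

Working notes. Among the measured compounds shown here, compound 2 `COC(=O)c1ccc(OCCCCOc2ccc(C(=O)CC3CCCC3)c(C)c2C)cc1` is one of two compounds measured in an assay on HEK293 cells for positive allosteric modulation of metabotropic glutamate receptor 3 (Rattus norvegicus), read by thallium flux, with a stated time of 2.5 min; on this read-out higher numbers stand for larger maximal responses and lower numbers for smaller maximal responses; compound 2 gives 24.2%, the lower of the two numbers. Compound 1 `Cc1c(OCCCCOc2ccc(C(=O)O)cc2)ccc(C(=O)CC2CCCC2)c1O`, which carries a carboxy group and a hydroxy on its core, gives in this assay 26.7%; the two values lie within the scatter of each other, so no order can be read from them. For the measured compounds named here, compound 1 and compound 2 differ in two places and no single step links them.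

Compound 3 `Cc1c(OCCCCOc2ccc(C(=O)O)cc2)ccc(C(=O)CC2CCCC2)c1C` has not yet been measured in this assay. It differs from compound 2 by hydrogen in place of methyl on an oxygen next to a carbonyl group.

Going by the values given here, no measured pair isolates this change. Given that compound 1, also a carboxy compound, gives 26.7%, the step of a number 0.8 percentage points higher from compound 2 to compound 3 (within the scatter) is expected to stay within the scatter. Compound 3 is therefore estimated at 25%, with a range from 14% to 38%.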

Compound 3, largest response reached (reported as percent of maximum), in percent of the reference or control that the assay uses: 12.2%
The estimate for compound 3 lay 12.8 percentage points above the measured number, outside the stated range (below it).
By their numbers in this assay, from the lowest: compound 3; then compounds 2 and 1 (each within the scatter of the next).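

In this assay, methoxycarbonyl to carboxy on the dimethyl-substituted core is a real change: hydrogen in place of methyl on an oxygen next to a carbonyl group gives a number 12 percentage points lower from compound 2 to compound 3 (beyond the scatter), so the ester and the acid do not read alike here. The hydroxy of compound 1 also counts once the carboxy group is present, since methyl in place of hydroxy on an aromatic carbon gives a number 14.5 percentage points lower from compound 1 to compound 3 (beyond the scatter) and leaves compound 3 lowest of the three. Nothing available explains either step.

Open, going by these compounds, is whether the ester-to-acid drop also holds on the core of compound 1, as these two steps meet only at compound 3. Also open, on these data alone, is how a primary amide or a tetrazole in place of the carboxy group would read in this assay on either core.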